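A few compounds are considered here, and "the series" means these few. Any claim that something is new, unique, unknown or untested is made for them only; others in the source may bear on it.

Of the compounds shown here, three sharing one core have been measured for cytotoxicity. In a functional assay on PC-3 cells (Homo sapiens) for cytotoxicity, read by sulforhodamine B assay (on this read-out lower numbers stand for stronger inhibition of growth and higher numbers for weaker inhibition of growth), compound 1 `COc1cccc(OC)c1OCCNCCOc1ccccc1OCc1ccccc1Cl` gives 5400 nM, compound 2 `COc1cccc(OC)c1OCCNCCOc1ccccc1OCc1cccc(Cl)c1` gives 5900 nM, and compound 3 `COc1cccc(OC)c1OCCNCCOc1ccccc1OCc1cccc(C)c1` gives 12000 nM. Between the first two there is a 1.1-fold higher number from compound 1 to compound 2 (0.04 log units; within the scatter), while there is a 2.2-fold higher number from compound 1 to compound 3 (0.35 log units; beyond the scatter) and a 2.0-fold higher number from compound 2 to compound 3 (0.31 log units; beyond the scatter); compound 3 therefore carries the highest number of the three, with both neighbours beyond the scatter below it.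

The next compound, compound 4 `CCOc1ccc(COc2ccccc2OCCNCCOc2c(OC)cccc2OC)cc1`, differs from compound 3 in a single place: 4-ethoxyphenyl in place of 3-methylphenyl on a saturated chain carbon bound to an oxygen on an aromatic ring. Within the data shown here, the steps that bear on such a change are the two that alter the group on that same carbon, and both were modest. Among the measured compounds shown here, none of the measured steps tested a group carrying an oxygen in the ring substituent, so the direction remains open. Compound 4 is expected to stay close to compound 3 in this assay, with an estimate of 9000 nM and a range from 3500 nM to 25000 nM. The step this estimate implies, a 1.3-fold lower number from compound 3 to compound 4 (0.12 log units; within the scatter), is expected to lie within the scatter.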

Compound 4, concentration for 50% growth inhibition: 5200 nM
Estimate against measurement, compound 4: 1.7-fold (0.24 log units) above, and the stated range covers the measured number.
By their numbers in this assay, from the lowest: compounds 4, 1 and 2 (each within the scatter of the next); then compound 3.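

In this assay, among these compounds, the 4-ethoxyphenyl group on this saturated chain carbon is the first here to carry an oxygen and a hydrogen-bond acceptor, and the change from 3-methylphenyl gives a 2.3-fold lower number from compound 3 to compound 4 (0.36 log units; beyond the scatter). The same group stands level with both chlorinated groups, with a 1.1-fold lower number from compound 2 to compound 4 (0.05 log units; within the scatter) and a 1.0-fold lower number from compound 1 to compound 4 (0.02 log units; within the scatter), so among these four compounds only compound 3 stands apart from the others. No supporting data accompany these results to explain the difference between compound 3 and compound 4.

The step from compound 3 to compound 4 changes both the substituent and its printed ring number, and these compounds cannot separate the two. From the compounds shown here alone, it also remains open whether a longer chain such as 4-butoxyphenyl, or an amine or a carboxylic acid on this ring, would move the number beyond this level.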